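Compound 4 beside three compounds at the assay ceiling

A few compounds are considered here, and "the series" means these few. Any claim that something is new, unique, unknown or untested is made for them only; others in the source may bear on it.

Compound 1 `Cc1ccc(-n2nncc2CN2C(=O)C3(C(C#N)=C(N)Oc4c3c3nc5ccccc5nc3c3ccccc43)c3ccccc32)cc1C` — in a functional assay on MCF7 cells (Homo sapiens) for antiproliferative activity, read by MTT assay, with a stated time of 48 h (on this read-out higher numbers stand for weaker inhibition and lower numbers for stronger inhibition), compound 1 gives > 50000 nM, a limit of the assay.
Compound 2 `N#CC1=C(N)Oc2c(c3nc4ccccc4nc3c3ccccc23)C12C(=O)N(Cc1cnnn1-c1ccc(F)c(Cl)c1)c1ccccc12` — in this assay compound 2 gives > 50000 nM, again a limit.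
Compound 3 `N#CC1=C(N)Oc2c(N)cc3nc4ccccc4nc3c2C12C(=O)N(Cc1cnnn1-c1ccc(F)cc1)c1ccccc12` — in this assay compound 3 gives > 50000 nM, also a limit.

Every value here is a limit and not a number: the limit of > 50000 nM in this assay, at which 3 of the 3 values shown sit. Compound 3 thus stands at that limit and nowhere more precise. Within the data shown here, the single one-place step, a step that the two limits leave unreadable from compound 1 to compound 2, cannot be read because both of its ends are limits.

Compound 4 `N#CC1=C(N)Oc2c(N)cc3nc4ccccc4nc3c2C12C(=O)N(Cc1cnnn1-c1ccc([N+](=O)[O-])cc1[N+](=O)[O-])c1ccccc12` differs from compound 3 in one place: 2,4-dinitrophenyl in place of 4-fluorophenyl on an aromatic nitrogen. Among the measured compounds shown here, no measured step touches this exchange of the group on the aromatic nitrogen in a readable way, and the one step that changes that same group is unreadable. The expectation for compound 4 can rest only on the three limits, and so a step that the limit leaves unreadable from compound 3 to compound 4 is expected, in no direction beyond the scatter. Compound 4 is therefore estimated at 60000 nM, within 15000 nM to 250000 nM, most probably reported as a limit once more.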

Compound 4, half-maximal inhibitory concentration: 20900 nM
Compound 4: middle estimate off by 2.9-fold (0.46 log units), on the high side; low and high end bracket the measured number.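

In this assay, among these compounds, the exchange on the aromatic nitrogen of the five-membered ring gives an at least 2.3-fold lower number from compound 3 to compound 4 (0.37 log units; beyond the scatter), the first readable step in this set. It shows that, on the core of compound 3, the group at this position can bring the number down from the assay ceiling, and that 2,4-dinitrophenyl does so where 4-fluorophenyl does not. The true size of the step remains open-ended, as compound 3 has only a limit, and compound 4 is the one compound with a number: the limit of > 50000 nM in this assay, at which 3 of the 4 values shown sit.

The compounds shown leave open whether a phenyl ring with a single nitro group, or with an amine in place of the nitro groups, would give a similar step. They also leave open whether 2,4-dinitrophenyl would have the same effect on the core of compound 1.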